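The source may hold more compounds than are shown below. What is called first, only, known or untested is meant among the compounds shown, and "the series" means these compounds.

Measured compounds:
Compound 1 `CC1CCN(C2CCN(S(=O)(=O)c3cn(C)cn3)CC2)CC1` gives > 10000 nM in an ADME assay on HCT-116 cells (Homo sapiens) for cytotoxicity, read by CellTiter-Glo, with a stated time of 72 h; on this read-out lower numbers stand for stronger inhibition and higher numbers for weaker inhibition; this value is a limit of the assay, not a number.
Compound 2 `Cc1cc(C)c(S(=O)(=O)N2CCN(C3CN4CCC3CC4)CC2)c(C)c1` gives > 5000 nM in this assay; this too is a limit.
Compound 3 `CC1CCN(C2CCN(S(=O)(=O)c3cccc4cnccc34)CC2)CC1` gives > 10000 nM in this assay; again only a limit.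

Compound 1 therefore stands nowhere in particular: only a limit is known for it, and the two other values shown are limits as well, as the limit of > 10000 nM in this assay, at which 2 of the 3 values shown sit, and the limit of > 5000 nM in this assay, at which 1 of the 3 values shown sits, record. For the measured compounds named here, no step between measured compounds exists, so nothing measured speaks to the size of any change. Compound 4 `Cc1ccc(S(=O)(=O)N2CCC(N3CCC(C)CC3)CC2)cc1C` differs from compound 1 in one place: 3,4-dimethylphenyl in place of 1-methyl-1H-imidazol-4-yl on a sulfonyl sulfur. With every value at a limit, the step that the limit leaves unreadable from compound 1 to compound 4 is expected to show no movement beyond the scatter. Compound 4 is thus expected to give about 15000 nM, in a range from 5000 nM to 50000 nM, most likely as another limit.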

Compound 4, half-maximal inhibitory concentration: > 5000 nM
Compound 4 gave a limit, no number (the forecaster's own chance of this, stated with the estimate: 85%); the middle value is on the limit's open side.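

Compound 1 and compound 4 both give only limits in this assay, and the step between them cannot be read. The compounds shown leave open whether 3,4-dimethylphenyl in place of 1-methyl-1H-imidazol-4-yl changes cytotoxicity at all.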